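This account rests on a few compounds, and the source may have more. Where it says the series, first, only, none or still open, it means among the compounds named here.

Three compounds sharing the core of compound 1, `Fc1ccccc1NC(=S)N/N=C/c1ccc2ccccc2n1`, have been tested in a functional assay on HL-60 cells (Homo sapiens) for antiproliferative activity, read by sulforhodamine B assay, with a stated time of 72 h; a lower number here means a stronger inhibitor, a higher number a weaker inhibitor. Compound 1 gives > 100000 nM, which is a limit of the assay and (the limit of > 100000 nM in this assay, at which 1 of the 3 values shown sits). Compound 2, `N#Cc1ccc(NC(=S)N/N=C/c2ccc3ccccc3n2)cc1`, gives 4660 nM in this assay, the larger change from compound 1 being an at least 21-fold lower number from compound 1 to compound 2 (1.33 log units; beyond the scatter). Compound 3, `S=C(N/N=C/c1ccc2ccccc2n1)Nc1cccc(Br)c1`, gives 53800 nM in this assay; that is the highest of the two numbers shown, its nearest neighbour being compound 2 through the step of a 12-fold higher number from compound 2 to compound 3 (1.06 log units; beyond the scatter), whereas an at least 1.8-fold lower number from compound 1 to compound 3 (0.26 log units; that floor lies within the scatter). Compound 4, `COc1cccc(NC(=S)N/N=C/c2ccc3ccccc3n2)c1`, has not yet been measured; it differs from compound 3 by methoxy in place of bromo on an aromatic carbon. For the measured compounds named here, none of the measured steps exchanges a group on the same ring position, so they bear on this change only indirectly: the one large step seen concerns the 4-cyanophenyl group, and the exchange of one halogen-bearing phenyl for another stayed within the scatter. A step of no more than the scatter is therefore expected, a 1.1-fold lower number from compound 3 to compound 4 (0.03 log units; within the scatter). Compound 4 is estimated at 50000 nM in this assay, within 15000 nM to 150000 nM.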

Compound 4, half-maximal inhibitory concentration: 71200 nM
The estimate for compound 4 lay 1.4-fold (0.15 log units) below the measured number; the range from low to high includes it.
By their numbers in this assay, from the lowest: compound 2; then compounds 3 and 4 (each within the scatter of the next). At a limit, above all of these: compound 1.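

At this position, on a six-membered aromatic ring of carbon only and meta to a large group, this assay does not separate methoxy from bromo (a 1.3-fold higher number from compound 3 to compound 4 (0.12 log units; within the scatter)), even though methoxy adds a hydrogen-bond acceptor that bromo lacks. The large gap to the 4-cyanophenyl compound now appears with a second group at this position (a 15-fold higher number from compound 2 to compound 4 (1.18 log units; beyond the scatter)), so it does not depend on bromo alone. The comparison with compound 1 gives only a floor (an at least 1.4-fold lower number from compound 1 to compound 4 (0.14 log units; that floor lies within the scatter)), and compound 1 stands at a limit of the assay: the limit of > 100000 nM in this assay, at which 1 of the 4 values shown sits.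

On these data alone, whether an amine or a carboxylic acid at this position would also leave the number unchanged remains open. The compounds shown also cannot separate the nitrile of compound 2 from the place where it sits.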